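The source may report more compounds than this note shows. Statements on the series, on what has been measured and on what is new or still open speak of the compounds shown alone.

Compound 1 `Nc1scc(CN2CCN(c3ccc(F)cc3Cl)CC2)c1C(=O)c1ccc(Cl)cc1` gives 0% in an assay on CHO cells for displacement of a labelled ligand from adenosine receptor A3 (Homo sapiens), read by scintillation counting, with a stated time of 120 min, tested at 10 uM (a higher number here means more inhibition at the concentration tested (going by the name of the read-out), a lower number less inhibition), the lowest of the three measured numbers, while compound 2 `Nc1scc(CN2CCN(c3ccc(OC(F)(F)F)cc3)CC2)c1C(=O)c1ccc(Cl)cc1` gives 1% and compound 3 `Nc1scc(CN2CCN(c3cc(F)cc(F)c3)CC2)c1C(=O)c1ccc(Cl)cc1` gives 2%. Compound 4 `Nc1scc(CN2CCN(c3cccc(F)c3F)CC2)c1C(=O)c1ccc(Cl)cc1` differs from compound 1 in one place: 2,3-difluorophenyl in place of 2-chloro-4-fluorophenyl on an amine nitrogen in a ring. Two measured steps likewise exchange the group on an amine nitrogen in a ring: a number 1 percentage points higher from compound 1 to compound 2 (within the scatter) and a number 2 percentage points higher from compound 1 to compound 3 (within the scatter). The remaining step, a number 1 percentage points higher from compound 2 to compound 3 (within the scatter), is also within the scatter. Since every exchange of this group so far left the inhibition essentially unchanged, compound 4 is expected to show no step beyond the scatter, a number 1 percentage points higher from compound 1 to compound 4 (within the scatter). Compound 4 is therefore estimated at 1%, with a range from -8% to 10%.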

Compound 4, a percentage reported as inhibition, at one concentration (the size of the read-out at that concentration, not a potency): 0%
Estimate against measurement, compound 4: 1 percentage points above; measured number inside the range.
By their numbers in this assay, from the lowest: compounds 1, 4, 2 and 3 (each within the scatter of the next).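

Swapping the chlorine-bearing 2-chloro-4-fluorophenyl for 2,3-difluorophenyl, with the heavy-atom count unchanged, left this assay flat (no change at the digits printed from compound 1 to compound 4 (within the scatter)). Two fluorines in a different arrangement also gave no step beyond the scatter (a number 2 percentage points lower from compound 3 to compound 4 (within the scatter)), and the same held against the 4-(trifluoromethoxy)phenyl group (a number 1 percentage points lower from compound 2 to compound 4 (within the scatter)). Nothing available explains why this position stays so silent.

As far as these compounds go, whether any group here can raise inhibition remains open, since all four compounds carry a halogen-containing phenyl. An aminophenyl, a carboxylic acid or a longer alkyl chain on that ring nitrogen could still behave differently.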